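Trifluoromethoxy for fluoro on the fluorophenyl arm

This account rests on a few compounds, and the source may have more. Where it says the series, first, only, none or still open, it means among the compounds named here.

Compound 3 `Oc1ccc(-c2cc(-c3cccc(F)c3)cc(-c3cccc(O)c3)n2)cc1` gives 14200 nM in a functional assay on HeLa cells (Homo sapiens) for inhibition (on this read-out higher numbers stand for weaker inhibition and lower numbers for stronger inhibition), the lowest of the two numbers in hand. Compound 2 `Oc1ccc(-c2cc(-c3ccccc3F)cc(-c3cccc(O)c3)n2)cc1` gives 14300 nM, and a 1.0-fold lower number from compound 2 to compound 3 (0.00 log units; within the scatter) shows that the two values sit together. For the measured compounds named here, compound 1 `Oc1ccc(-c2cc(-c3cccc(F)c3)cc(-c3ccccc3O)n2)cc1` reaches only the assay limit, > 50000 nM. an at least 3.5-fold lower number from compound 1 to compound 3 (0.54 log units; beyond the scatter) is the one change beyond the scatter in the set, and it concerns the hydroxyphenyl arm, not the fluorophenyl one.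

Compound 4 `Oc1ccc(-c2cc(-c3cccc(OC(F)(F)F)c3)cc(-c3cccc(O)c3)n2)cc1` differs from compound 3 by trifluoromethoxy in place of fluoro on an aromatic carbon, the new group sitting on an aromatic carbon of a six-membered aromatic ring of carbon only, meta to a large group. Going by the values given here, of the measured steps only a 1.0-fold lower number from compound 2 to compound 3 (0.00 log units; within the scatter) touches the fluorophenyl arm, and it moved nothing beyond the scatter; no measured step swaps a fluoro for a larger group, so the size of the present change has no direct precedent. The expectation is therefore a step of a 1.0-fold lower number from compound 3 to compound 4 (0.01 log units; within the scatter) in this assay, with no direction beyond the scatter. Compound 4 is estimated at 14000 nM, range 5000 nM to 40000 nM.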

Compound 4, half-maximal inhibitory concentration: 14100 nM
Compound 4: the middle estimate sits 1.0-fold (0.00 log units) below what was measured, within the range that was stated.
By their numbers in this assay, from the lowest: compounds 4, 3 and 2 (each within the scatter of the next). At a limit, above all of these: compound 1.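

In this assay the change on the fluorophenyl arm gives a 1.0-fold lower number from compound 3 to compound 4 (0.00 log units; within the scatter). This position, on an aromatic carbon meta to a large group, therefore accepts trifluoromethoxy, with 5 heavy atoms against 1 for fluoro and 1 hydrogen-bond acceptor against 0, without a difference beyond the scatter, something the earlier fluoro-only compounds could not show. Neither compound 3 nor compound 4 sits at a limit, so this step compares two read numbers: the limit of > 50000 nM in this assay, at which 1 of the 4 values shown sits.

From the compounds shown here alone, whether the same holds for an amine, a carboxylic acid or a longer chain at this position remains open. Also open is whether any group on this arm can shift the number beyond the scatter, since the one such step shown so far lies on the hydroxyphenyl arm.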